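A few compounds are considered here, and "the series" means these few. Any claim that something is new, unique, unknown or untested is made for them only; others in the source may bear on it.

Compound 1 `CC(=O)OC1C#CCCCCC#C/C1=C\c1ccccc1` and compound 3 `COCC(=O)OC1C#CCCCCC#C/C1=C\c1ccccc1` share one core and differ in a single place. methoxy in place of hydrogen on a saturated chain carbon bound to a carbonyl carbon In a functional assay on P388 cells (Mus musculus) for inhibition, read by MTT assay (on this read-out lower numbers stand for stronger inhibition and higher numbers for weaker inhibition), compound 1 gives 48000 nM, and compound 3 gives 23000 nM. That change made a 2.1-fold lower number from compound 1 to compound 3 (0.32 log units; beyond the scatter). Compound 2 `CC(=O)OC1C#CCCCCC#C/C1=C\c1cccc2ccccc12` is built on another core; the difference between the two cores is not broken down here. In this assay compound 2 gives 2400 nM, the lowest of the three numbers. For the measured compounds named here, compound 4 `COCC(=O)OC1C#CCCCCC#C/C1=C\c1cccc2ccccc12` has not yet been measured and stands to compound 2 as compound 3 stands to compound 1. methoxy in place of hydrogen on a saturated chain carbon bound to a carbonyl carbon Since the only measured instance of this change is a 2.1-fold lower number from compound 1 to compound 3 (0.32 log units; beyond the scatter), a step of the same kind and similar size is expected, namely a 2.0-fold lower number from compound 2 to compound 4 (0.30 log units; within the scatter). Compound 4 is therefore estimated at 1200 nM, likely between 500 nM and 3000 nM.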

Compound 4, half-maximal inhibitory concentration: 12000 nM
Estimate against measurement, compound 4: 10-fold (1.00 log units) below, outside the stated range (above it).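

On the second core, methoxy in place of hydrogen on a saturated chain carbon bound to a carbonyl carbon gives a 5.0-fold higher number from compound 2 to compound 4 (0.70 log units; beyond the scatter) in this assay. Set beside the earlier step, the same change moves the number in opposite directions on the two cores: the same change on two cores in this assay, a 2.1-fold lower number (0.32 log units; beyond the scatter) from compound 1 to compound 3 and a 5.0-fold higher number (0.70 log units; beyond the scatter) from compound 2 to compound 4, 10-fold (1.02 log units) apart, beyond the scatter of two such steps. Its effect therefore cannot simply be carried from one core to the other in this series, though two pairs do not show what in the cores causes the split or how a third core would respond.

Still open, as far as these compounds go, is whether an amine or a longer chain in the same place would also differ between the two cores. The compounds shown cover only the methoxy change, so they cannot say whether this split is special to it.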